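Amide variation on the shared core: toxicity notes

The compounds below may be only part of what the source reports. "The series", "measured", "known", "first", "only" and "open" are said of these compounds alone.

Compound 1 `COc1ccc(-c2cnc(NC(=O)C3CCCCC3)n2C)cc1`: in a toxicity assay on THP-1 cells (Homo sapiens) for inhibition (on this read-out lower numbers stand for higher toxicity in this test and higher numbers for lower toxicity in this test), compound 1 gives only a limit, > 100000 nM.
Compound 2 `COc1ccc(-c2cnc(NC(=O)c3ccn[nH]3)n2C)cc1`: in this assay compound 2 gives only a limit, > 100000 nM.
Compound 3 `COc1ccc(-c2cnc(NC(=O)c3ccccc3Br)n2C)cc1`: in this assay compound 3 gives only a limit, > 100000 nM.

Compound 3 stands at the limit of this assay, as do all values shown so far (the limit of > 100000 nM in this assay, at which 3 of the 3 values shown sit). The steps a step that the two limits leave unreadable from compound 1 to compound 2, a step that the two limits leave unreadable from compound 1 to compound 3 and a step that the two limits leave unreadable from compound 2 to compound 3 are each not readable. Compound 4 `COc1ccc(-c2cnc(NC(=O)c3ccccc3O)n2C)cc1` differs from compound 3 by hydroxy in place of bromo on an aromatic carbon, the amide side going from 2-bromophenyl to 2-hydroxyphenyl. Among the compounds with values here, no measured step bears readably on this change; every value shown sits at the limit. The expected step of a number no higher from compound 3 to compound 4 (the limit leaves the size open) is therefore none beyond the scatter, with compound 4 most likely again reported only as a limit. Compound 4 is estimated at 100000 nM, range 50000 nM to 200000 nM.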

Compound 4, half-maximal cytotoxic concentration: > 100000 nM
Compound 4 ended at the assay's limit; the forecaster's own chance of this, stated with the estimate: 80%; the middle value lies on the limit itself.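

Within the data shown here, compound 4, like compound 1, compound 2 and compound 3, gives only a limit, so no step among them can be read: the limit of > 100000 nM in this assay, at which 4 of the 4 values shown sit. The compounds shown leave open whether any amide side on the shared core gives a readable number in this assay at all.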